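Cytotoxicity notes on a nucleoside series: phenyl to furanyl

A few compounds are considered here, and "the series" means these few. Any claim that something is new, unique, unknown or untested is made for them only; others in the source may bear on it.

Measured in an ADME assay on MRC5 cells (Homo sapiens), read by MTT assay, with a stated time of 72 h; on this read-out higher numbers stand for weaker inhibition and lower numbers for stronger inhibition:
compound 1 `COc1nc(N)nc2c1c(-c1ccccc1)cn2[C@@H]1O[C@H](CO)[C@@H](O)[C@H]1O` — > 100000 nM (a limit of the assay)
compound 2 `COc1ncnc2c1c(-c1ccccc1)cn2[C@@H]1O[C@H](CO)[C@@H](O)[C@H]1O` — > 100000 nM (a limit of the assay)

Compound 1 reaches only the limit > 100000 nM in this assay. Compound 2 likewise gives only the limit > 100000 nM. Within the data shown here, the one measured step, a step that the two limits leave unreadable from compound 1 to compound 2, is therefore not readable in size, since both ends sit at the limit of > 100000 nM in this assay, at which 2 of the 2 values shown sit. Compound 2 thus stands at the limit of this assay, with no number to place it against any other compound.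

Compound 3 `COc1ncnc2c1c(-c1ccoc1)cn2[C@@H]1O[C@H](CO)[C@@H](O)[C@H]1O` is not yet measured. It differs from compound 2 by furan-3-yl in place of phenyl on an aromatic carbon. Among the measured compounds shown here, no measured step involves this change, and the only measured step, a step that the two limits leave unreadable from compound 1 to compound 2, has no readable size, so there is nothing to set an expected direction or magnitude. Nothing here points to compound 3 leaving the limit, and the expectation is that it too sits at or near it, an expected step that the limit leaves unreadable from compound 2 to compound 3 within the scatter. Compound 3 is estimated at 150000 nM, between 50000 nM and 500000 nM.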

Compound 3, half-maximal inhibitory concentration: 29400 nM
Estimate against measurement, compound 3: 5.1-fold (0.71 log units) above; the measured number lies below the stated range.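

In this assay, among these compounds, the aromatic carbon two ring bonds from the ring nitrogen is the first place where a change yields a number instead of a limit: furan-3-yl in place of phenyl gives an at least 3.4-fold lower number from compound 2 to compound 3 (0.53 log units; beyond the scatter). The group at this place therefore matters to the read-out, whereas the amino-to-hydrogen change on the core showed nothing, its step being unreadable with a limit at both ends. The step from phenyl sets only a minimum size, with no number at the phenyl end: the limit of > 100000 nM in this assay, at which 2 of the 3 values shown sit.

From the compounds shown here alone, whether the shift follows the smaller five-membered ring or the ring oxygen, the one hydrogen-bond acceptor that enters, stays open, and a thienyl or a pyridyl group at the same place would help separate the two. Also open, going by these compounds, is whether the amino group on the core, restored alongside furan-3-yl, would alter the value, and whether any other group at this place, such as a small alkyl chain, would leave the limit at all.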